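Swapping a Carboxylate Tail for a Sulfate Group

This account rests on a few compounds, and the source may have more. Where it says the series, first, only, none or still open, it means among the compounds named here.

Compound 1, `CCN(CC(=O)NC[C@H]1O[C@H](OC)[C@@H](OS(=O)(=O)O)[C@@H](OS(=O)(=O)O)[C@@H]1OS(=O)(=O)O)C(=O)CCc1ccccc1`, gives 596000 nM in an assay on isolated protein for binding affinity to vascular endothelial growth factor A, long form (Homo sapiens), read by surface plasmon resonance; a lower number here means tighter binding, a higher number weaker binding.
Compound 2, `CCN(CC(=O)NC[C@H]1O[C@H](OC)[C@@H](OS(=O)(=O)O)[C@@H](OS(=O)(=O)O)[C@@H]1OS(=O)(=O)O)C(=O)CCCCC(=O)O`, gives 104000 nM in this assay.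
Compound 3, `CCN(CC(=O)NC[C@H]1O[C@H](OC)[C@@H](OS(=O)(=O)O)[C@@H](OS(=O)(=O)O)[C@@H]1OS(=O)(=O)O)C(=O)CCCCCCCCCOS(=O)(=O)O`, gives 545000 nM in this assay.

All three share one core and differ only in the tail attached through the amide. Compound 2 has the lowest number of the three: the step of a 5.7-fold lower number from compound 1 to compound 2 (0.76 log units; beyond the scatter) and the step of a 5.2-fold higher number from compound 2 to compound 3 (0.72 log units; beyond the scatter) both lie beyond the scatter, so compound 2 binds tightest among them.

Compound 4, `CCN(CC(=O)NC[C@H]1O[C@H](OC)[C@@H](OS(=O)(=O)O)[C@@H](OS(=O)(=O)O)[C@@H]1OS(=O)(=O)O)C(=O)COS(=O)(=O)O`, has not yet been measured. Its change from compound 2 is sulfooxy in place of 3-carboxypropyl on a saturated chain carbon bound to a carbonyl carbon. Among the compounds with values here, two measured steps bear on this. The step of a 5.2-fold higher number from compound 2 to compound 3 (0.72 log units; beyond the scatter) shows that giving up the carboxy end in favour of a sulfooxy-bearing tail costs a modest amount, and the step of a 5.7-fold lower number from compound 1 to compound 2 (0.76 log units; beyond the scatter) shows that the carboxy end is what sets compound 2 apart. Within the data shown here, compound 4 likewise loses the carboxy and gains a sulfooxy, though compound 3 carries its sulfooxy on a 5-(sulfooxy)pentyl whereas compound 4 carries it directly on the saturated chain carbon bound to the carbonyl carbon; no measured pair tells how that difference matters. A modest rise in the number is therefore expected, a 2.9-fold higher number from compound 2 to compound 4 (0.46 log units; beyond the scatter). Compound 4 is estimated to give 300000 nM, between 100000 nM and 900000 nM, in this assay.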

Compound 4, dissociation constant: 512000 nM
The estimate for compound 4 lay 1.7-fold (0.23 log units) below the measured number; the measured number falls inside the stated range.
By their numbers in this assay, from the lowest: compound 2; then compounds 4, 3 and 1 (each within the scatter of the next).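

The change to sulfooxy from 3-carboxypropyl, on a saturated chain carbon bound to a carbonyl carbon, gives a 4.9-fold higher number from compound 2 to compound 4 (0.69 log units; beyond the scatter) in this assay, while the change to sulfooxy from benzyl at that place gives a 1.2-fold lower number from compound 1 to compound 4 (0.07 log units; within the scatter) and so shows no readable change. In the same assay compound 4 gives 512000 nM and compound 3 gives 545000 nM, two values within the scatter of each other, so among these two tails the long chain of compound 3 and the short one of compound 4 cannot be told apart. Among the four compounds, only compound 2, the one with a carboxy end on its tail, stands apart from the others, and nothing measured here accounts for that.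

The compounds shown leave open whether a carboxylic acid on a shorter chain than the 4-carboxybutyl of compound 2 would keep that lower number, or whether a longer chain would. They also leave open how an amine at the end of the tail would compare with the carboxy end and the sulfooxy end.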